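Trifluoromethyl for methyl on the shared core

This account rests on a few compounds, and the source may have more. Where it says the series, first, only, none or still open, it means among the compounds named here.

Compound 2 `Cc1ccc2[nH]c(-n3[nH]c(C)c(Cc4ccccc4)c3=O)nc2c1` carries a phenyl on a saturated chain carbon and a methyl on its fused ring. In a functional assay on DU-145 cells (Homo sapiens) for antiproliferative activity, read by WST assay, with a stated time of 48 h, tested at 10 uM (a higher number here means a stronger effect of the compound at the concentration tested, a lower number a weaker effect), compound 2 gives 54%. Compound 3 `Cc1ccc2[nH]c(-n3[nH]c(C)c(C)c3=O)nc2c1` differs only in having hydrogen in place of that phenyl, and in this assay compound 3 gives 19%. The change is a number 35 percentage points lower from compound 2 to compound 3 (beyond the scatter). Compound 1 `Cc1[nH]n(-c2nc3cc(Cl)ccc3[nH]2)c(=O)c1Cc1ccccc1` shares the core, and in this assay compound 1 gives "not determined" (no result reported), so compound 2 stands highest of the two numbers available.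

Compound 4 `Cc1[nH]n(-c2nc3cc(C(F)(F)F)ccc3[nH]2)c(=O)c1Cc1ccccc1` is reached from compound 2 by a change at a different place: trifluoromethyl in place of methyl on an aromatic carbon. Going by the values given here, the only measured step, the large one from compound 2 to compound 3, concerns the saturated chain carbon and not the aromatic carbon of the fused ring, so no measured step bears directly on this change. With nothing to show that a change at this aromatic carbon moves the read-out, the expectation is a step no larger than the scatter, in either direction; for compound 4 the expected step is a number 2 percentage points lower from compound 2 to compound 4 (within the scatter). Compound 4 is therefore estimated at 52%, with a range from 28% to 74%.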

Compound 4, a percentage reported as inhibition, at one concentration (the size of the read-out at that concentration, not a potency): 84%
Estimate against measurement, compound 4: 32 percentage points below; the whole stated range lies below it.
By their numbers in this assay, from the lowest: compound 3; then compound 2; then compound 4.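

Trifluoromethyl in place of methyl on this aromatic carbon gives a clear gain in this assay, with a number 30 percentage points higher from compound 2 to compound 4 (beyond the scatter), so this carbon of the fused ring is a place where a single change can move the read-out. Going by these compounds alone, until this result, the only measured change lay on the saturated chain carbon, where a number 35 percentage points lower from compound 2 to compound 3 (beyond the scatter); the shared core now has two places at which a change goes beyond the usual scatter, one on the chain and one on the ring. No measurement at hand accounts for the rise, which is a read-out at a single concentration and not a potency.

On these data alone, one swap at one carbon gives no trend, so it remains open whether a nitrile, a methoxy group or an amine on this aromatic carbon would raise the read-out, lower it or leave it unchanged. Also open, as far as these compounds go, is whether the phenyl on the saturated chain carbon matters as much when trifluoromethyl stands on the ring, since the step for that phenyl is known only with methyl in place.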